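This account rests on a few compounds, and the source may have more. Where it says the series, first, only, none or still open, it means among the compounds named here.

Measured compounds in a functional assay on RXF 393 cells (Homo sapiens) for cytotoxicity, read by sulforhodamine B assay, with a stated time of 48 h; on this read-out higher numbers stand for lower toxicity in this test and lower numbers for higher toxicity in this test:

compound 1, `ClCc1cccc(Cn2cnc3c(Cl)ncnc32)c1`, gives 70800 nM
compound 2, `ClCc1cccc(Cn2cnc3c(Cl)nc(Cl)nc32)c1`, gives 5120 nM
compound 3, `ClCc1ccccc1Cn1cnc2ncnc(Cl)c21`, gives > 100000 nM, which is a limit of the assay and not a number

Compound 1 and compound 2 share a core and differ in one place: chloro in place of hydrogen on an aromatic carbon
in words: chloro in place of hydrogen on an aromatic carbon. This change gave a 14-fold lower number from compound 1 to compound 2 (1.14 log units; beyond the scatter) in this assay.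

Compound 3 carries the same atoms as compound 1, joined differently; the difference between the two cores is not broken down here. For compound 3 only a limit is known, and that limit is the limit of > 100000 nM in this assay, at which 1 of the 3 values shown sits.

Compound 4, `ClCc1ccccc1Cn1cnc2nc(Cl)nc(Cl)c21`, is not yet measured. It differs from compound 3 by chloro in place of hydrogen on an aromatic carbon
in words: chloro in place of hydrogen on an aromatic carbon. The place of this change is described in the same words as for the change from compound 1 to compound 2, so it is the same change on the other core.

For compound 4 in this assay the step of an at least 6.6-fold lower number from compound 3 to compound 4 (0.82 log units; beyond the scatter) is expected, on the assumption that the change does on the core of compound 3 roughly what it did as a 14-fold lower number from compound 1 to compound 2 (1.14 log units; beyond the scatter). Because the starting point for compound 3 is only > 100000 nM, the step is anchored to a limit and the expectation is broad. Compound 4 is estimated at 15000 nM, with a range from 5000 nM to 100000 nM.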

Compound 4, concentration lethal to 50% of the cells: 6450 nM
Estimate against measurement, compound 4: 2.3-fold (0.37 log units) above; the measured number falls inside the stated range.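

In this assay, chloro in place of hydrogen on an aromatic carbon, on the carbon between two ring nitrogen atoms, gave an at least 15-fold lower number from compound 3 to compound 4 (1.19 log units; beyond the scatter), so on these two cores the change moved the number in the same direction, towards higher toxicity in this test: the same change on two cores in this assay, a 14-fold lower number (1.14 log units; beyond the scatter) from compound 1 to compound 2 and an at least 15-fold lower number (1.19 log units; beyond the scatter) from compound 3 to compound 4; the limit leaves it open whether they differ

The value of compound 3 is a limit of the assay and not a number: the limit of > 100000 nM in this assay, at which 1 of the 4 values shown sits.

The pair of steps therefore supports carrying the direction of the change from the core of compound 1 to the core of compound 3, but it does not show that the size of the step is the same on both, and two cores make no general rule for the series.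

The compounds shown leave open whether another group in the same place, such as an amine, a carboxylic acid or a longer chain, would give a step like that of chloro. They also leave open whether the step seen in this assay would hold on further cores or in other cell lines.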